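The source may report more compounds than this note shows. Statements on the series, on what has been measured and on what is new or still open speak of the compounds shown alone.

Of the compounds shown here, two with a shared core have so far been measured in a functional assay on EA.hy 926 cells (Homo sapiens) for cytotoxicity, read by MTT assay, with stated times of 24 h and 12 h, tested at 12.5 uM; a lower number here means a weaker effect, a higher number a stronger effect of the compound at the concentration tested. Compound 1 `CCOC(=O)/C=C/c1cc(OC)ccc1OC(=O)c1nc(C)c(C)nc1C` gives 15.9% in this assay, and compound 2 `CCOC(=O)/C=C/c1ccc(OC(=O)c2nc(C)c(C)nc2C)cc1` gives 42.7%; compound 1 thus stands lowest of the two numbers, with compound 2 higher by a gap that goes beyond the usual scatter. The next compound, compound 3 `CCOC(=O)/C=C/c1cc(Cl)ccc1OC(=O)c1nc(C)c(C)nc1C`, keeps the core of compound 1 and differs from it in one place: chloro in place of methoxy on an aromatic carbon. Going by the values given here, no pair of measured compounds differs in only one place, so no measured step shows how such a swap acts here, and the expectation rests on compound 1 alone. Without a measured guide, the step is expected to be small, a modest rise at most, as a number 5.1 percentage points higher from compound 1 to compound 3 (within the scatter). Compound 3 is therefore estimated to give 21% in this assay, within a range from 8% to 38%.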

Compound 3, a percentage reported as activity, at one concentration (the size of the read-out at that concentration, not a potency): 64.9%
Beside the measured number, compound 3's estimate is 43.9 percentage points below it, and the stated range ends below it.
By their numbers in this assay, from the lowest: compound 1; then compound 2; then compound 3.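

At the aromatic carbon meta to a 2-(ethoxycarbonyl)ethenyl group and para to a large group, the choice of substituent matters greatly in this assay: chloro in place of methoxy gives a number 49 percentage points higher from compound 1 to compound 3 (beyond the scatter). Going by these compounds alone, this is the first measured sign that one small swap at this position can strongly change the read-out at the concentration tested, with a methoxy group, which counts as a hydrogen-bond acceptor, giving way to a single chlorine atom, which does not. Nothing measured here explains why this swap has such a large effect.

From the compounds shown here alone, it remains open whether other groups at this position, such as fluoro, bromo, methyl or an amine, would give numbers closer to those of chloro or methoxy. Also open, going by these compounds, is whether the same swap would act alike if a carboxylic acid replaced the ethyl ester.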